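Aryl amine swap on the shared core: compound 3 to 4

A few compounds are considered here, and "the series" means these few. Any claim that something is new, unique, unknown or untested is made for them only; others in the source may bear on it.

Three measured members of this series share a core in which two aryl groups sit on different nitrogens. Compound 1 `O=C(CSc1nc(Nc2ccccc2)c2ccccc2n1)Nc1cccc(F)c1` gives 6790 nM in a functional assay on NCI-H1975 cells (Homo sapiens) for inhibition, read by MTT assay, with a stated time of 72 h; a lower number here means a stronger inhibitor, a higher number a weaker inhibitor. For the measured compounds named here, compound 2 `O=C(CSc1nc(Nc2ccccc2)c2ccccc2n1)Nc1ccc(Cl)cc1Cl` gives 8410 nM in this assay; the one step between measured compounds, a 1.2-fold higher number from compound 1 to compound 2 (0.09 log units; within the scatter), shows that changing the aryl group on the amide-type nitrogen has so far left the number where it was. Compound 3 `C=CC(=O)Nc1cccc(NC(=O)CSc2nc(Nc3ccccc3C)c3ccccc3n2)c1` gives 9920 nM in this assay, the highest of the three numbers, but its gaps to compound 2 and to compound 1 are both within the scatter, so no order among the three can be read.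

Compound 4 `C=CC(=O)Nc1cccc(NC(=O)CSc2nc(Nc3ccc(Br)cc3)c3ccccc3n2)c1` differs from compound 3 in one place: 4-bromophenyl in place of 2-methylphenyl on a nitrogen on an aromatic ring. Going by the values given here, no measured step bears on this nitrogen on an aromatic ring; the only step available, a 1.2-fold higher number from compound 1 to compound 2 (0.09 log units; within the scatter), concerns the other aryl group and was itself within the scatter. Among the compounds with values here, with the sole measured change showing no movement, and nothing measured at the site of this change, the expectation for compound 4 is a step within the scatter, a 1.0-fold lower number from compound 3 to compound 4 (0.02 log units; within the scatter), and the estimated value for compound 4 in this assay is 9500 nM, with a range from 3000 nM to 30000 nM.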

Compound 4, half-maximal inhibitory concentration: 6280 nM
Compound 4: the middle estimate sits 1.5-fold (0.18 log units) above what was measured, within the range that was stated.
By their numbers in this assay, from the lowest: compounds 4, 1, 2 and 3 (each within the scatter of the next).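

In this assay, for the compounds shown here, the change at the nitrogen on an aromatic ring, (2-methylphenyl)amino to (4-bromophenyl)amino, gives a 1.6-fold lower number from compound 3 to compound 4 (0.20 log units; within the scatter), so a first reading at this position shows no movement beyond the scatter, as at the amide-type nitrogen, where the earlier step was a 1.2-fold higher number from compound 1 to compound 2 (0.09 log units; within the scatter). The entering and leaving groups match in heavy-atom count, each with one six-membered aromatic ring of carbon only and no hydrogen-bond donors or acceptors, yet they differ in both the substituent and its place on the ring, so this single step cannot separate those two changes. No measurement is available here to explain the result or to connect it to any property of either group.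

Still open, from the compounds shown here alone, is whether this nitrogen would tolerate a different kind of substituent, such as an amine or a carboxylic acid on the aryl ring, or a longer alkyl chain in place of that ring. The contribution of the acrylamide group to the number in this assay also remains open, with no pair among the compounds shown differing in that group alone.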